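Tosylation of the phenol in compound 3

The source may report more compounds than this note shows. Statements on the series, on what has been measured and on what is new or still open speak of the compounds shown alone.

Measured compounds:
- compound 1, `C=C1C[C@]23C[C@@]1(O)CC[C@H]2c1ccc(OS(=O)(=O)c2ccc(C)cc2)c(C)c1[C@@H]3Cn1cc(-c2ccc(OC)cc2)nn1`: > 20000 nM
- compound 2, `C=C1C(=O)[C@]23C[C@@]1(O)CC[C@H]2c1ccc(O)c(C)c1[C@@H]3Cn1cc(-c2ccc(C(F)(F)F)cc2)nn1`: 370 nM
- compound 3, `C=C1C(=O)[C@]23C[C@@]1(O)CC[C@H]2c1ccc(O)c(C)c1[C@@H]3Cn1cc(-c2ccc(C)cc2)nn1`: 330 nM

In a functional assay on SW480 cells (Homo sapiens) for cytotoxicity, read by MTT assay, with a stated time of 4 days (on this read-out higher numbers stand for weaker inhibition and lower numbers for stronger inhibition), compound 3 gives 330 nM, the lowest of the two numbers, and the step of a 1.1-fold lower number from compound 2 to compound 3 (0.05 log units; within the scatter) is within the scatter. The value of compound 1 is a limit of this assay, (the limit of > 20000 nM in this assay, at which 1 of the 3 values shown sits). Compound 4, `C=C1C(=O)[C@]23C[C@@]1(O)CC[C@H]2c1ccc(OS(=O)(=O)c2ccc(C)cc2)c(C)c1[C@@H]3Cn1cc(-c2ccc(C)cc2)nn1`, carries (4-methylphenyl)sulfonyl in place of hydrogen on an oxygen on an aromatic ring. Within the data shown here, no measured step covers this change; the only compound bearing the ((4-methylphenyl)sulfonyl)oxy group is compound 1, which sits at the limit. The number for compound 4 is therefore expected to rise: the estimated step is a 7.6-fold higher number from compound 3 to compound 4 (0.88 log units; beyond the scatter). The value expected for compound 4 is 2500 nM, within 500 nM to 20000 nM.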

Compound 4, half-maximal inhibitory concentration: 1460 nM
Compound 4: the middle estimate sits 1.7-fold (0.23 log units) above what was measured; measured number inside the range.
By their numbers in this assay, from the lowest: compounds 3 and 2 (each within the scatter of the next); then compound 4. At a limit, above all of these: compound 1.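

Earlier compounds changed only the far end of the molecule, whereas this pair shows what happens at the oxygen on the aromatic ring. In this assay, replacing the hydrogen of the hydroxy with (4-methylphenyl)sulfonyl gives a 4.4-fold higher number from compound 3 to compound 4 (0.65 log units; beyond the scatter) and still leaves a measurable number, so a free hydroxy here is not essential for cytotoxicity. Nothing measured here explains the rise.

The compounds shown leave open whether any group on this oxygen raises the number, or only this one. A methyl or acetyl group there could separate those two possibilities.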